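Chloro addition on the benzyl ring in two isatin-type cores

The source may hold more compounds than are shown below. What is called first, only, known or untested is meant among the compounds shown, and "the series" means these compounds.

Measured so far:
compound 1 `CC1(C)C(=O)Nc2ccc(OCc3cccc(Cl)c3)cc21`: 21.1%
compound 2 `O=C1Nc2ccc(OCc3cccc(Cl)c3)cc2C1=O`: 93%
compound 3 `CC1(C)C(=O)Nc2ccc(OCc3ccc(Cl)c(Cl)c3)cc21`: 28.8%

Three compounds have been run in an assay on cells for inhibition of Amine oxidase [flavin-containing] B (Homo sapiens), read by fluorescence, with stated times of 30 min and 15 min, tested at 1 uM; a higher number here means more inhibition at the concentration tested (going by the name of the read-out), a lower number less inhibition. Compound 1 and compound 3 share one core; compound 2 carries a different core, and the difference between the two cores is not broken down here. Compound 2 stands highest of the three in this assay, with compound 3 nearest, and both compound 1 and compound 3 lie beyond the scatter below it.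

Within the core of compound 1, the change chloro in place of hydrogen on an aromatic carbon gives the step of a number 7.7 percentage points higher from compound 1 to compound 3 (within the scatter), which stays within the scatter. The same change is now to be applied to the core of compound 2, yielding compound 4 `O=C1Nc2ccc(OCc3ccc(Cl)c(Cl)c3)cc2C1=O`, where the change is chloro in place of hydrogen on an aromatic carbon; the place lines of the two changes match word for word, so it is the same change on a different core. Going by the values given here, the only measured precedent for this change is compound 1 to compound 3, and the available data say nothing about whether the two cores respond alike.

Given that compound 2 already gives 93% in this assay, there is little room for an upward step; compound 4 is estimated at 92%, with a range from 80% to 98%. The expected step of a number 1 percentage points lower from compound 2 to compound 4 (within the scatter) rests on the near-flat step a number 7.7 percentage points higher from compound 1 to compound 3 (within the scatter) and on the high starting value of compound 2.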

Compound 4, a percentage reported as inhibition, at one concentration (the size of the read-out at that concentration, not a potency): 95.7%
Compound 4: middle estimate off by 3.7 percentage points, on the low side; low and high end bracket the measured number.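

In this assay, chloro in place of hydrogen on an aromatic carbon gives a number 2.7 percentage points higher from compound 2 to compound 4 (within the scatter), so on the core of compound 2 the change leaves the read-out essentially where it was. Set beside the earlier step, the change shows no difference between the two cores that can be told apart: the same change on two cores in this assay, a number 7.7 percentage points higher (within the scatter) from compound 1 to compound 3 and a number 2.7 percentage points higher (within the scatter) from compound 2 to compound 4, 5 percentage points apart, within the scatter of two such steps. Going by these compounds alone, this does not show that the two cores respond alike in general, since only two steps are at hand and compound 2 at 93% and compound 4 at 95.7% both sit close to the top of a percentage scale, where a reading at one concentration leaves little room for an upward step to appear.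

The compounds shown leave open whether compound 2 and compound 4 would separate in a full concentration series, which a reading at one concentration cannot tell. They also leave open how the two cores would respond to a group other than chloro on this aromatic carbon, such as a nitrile, a methoxy group or an amine, and whether the two cores would still track each other there.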